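This account rests on a few compounds, and the source may have more. Where it says the series, first, only, none or still open, it means among the compounds named here.

Measured compounds in a functional assay on SF-539 cells (Homo sapiens) for cytotoxicity, read by sulforhodamine B assay, with a stated time of 48 h, tested at 0.1 uM; a higher number here means a weaker effect of the compound at the concentration tested, a lower number a stronger effect:

compound 1 `COc1cc(-c2cc(/C=C/C(=O)c3ccc(N)cc3)[nH]n2)cc(OC)c1OC`: 99%
compound 2 `COc1ccc(-c2cc(/C=C/C(=O)c3ccc(N)cc3)[nH]n2)cc1OC`: 97%
compound 3 `COc1cc(C(=O)/C=C/c2cc(-c3cc(OC)c(OC)c(OC)c3)n[nH]2)cc(OC)c1OC`: 91%

Compound 2 is derived from compound 1 by the change (hydrogen in place of methoxy on an aromatic carbon). In this assay this gives a number 2 percentage points lower from compound 1 to compound 2 (within the scatter), so the two numbers cannot be told apart. Compound 3 is built on a different core; the difference between the two cores is not broken down here. Its number in this assay sits within the scatter of both compound 2 and compound 1, so none of the three can be ranked against the others at this concentration.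

Compound 4 `COc1ccc(-c2cc(/C=C/C(=O)c3cc(OC)c(OC)c(OC)c3)[nH]n2)cc1OC` has not yet been measured. It is derived from compound 3 by hydrogen in place of methoxy on an aromatic carbon. The place description matches that of the change from compound 1 to compound 2 word for word, so this is the same change applied to the core of compound 3.

The expected step for compound 4 in this assay is a number 1 percentage points lower from compound 3 to compound 4 (within the scatter), because the same change produced a number 2 percentage points lower from compound 1 to compound 2 (within the scatter). With only a single earlier occurrence of this change, and that one within the scatter, the expectation is essentially that compound 4 stays near compound 3. The estimate for compound 4 in this assay is 90%, expected to fall between 80% and 99%.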

Compound 4, a percentage reported as activity, at one concentration (the size of the read-out at that concentration, not a potency): 81%
Compound 4: the middle estimate sits 9 percentage points above what was measured; low and high end bracket the measured number.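

In this assay, hydrogen in place of methoxy on an aromatic carbon gives a number 10 percentage points lower from compound 3 to compound 4 (within the scatter), and set beside the earlier occurrence of the same change, the two steps cannot be told apart: the same change on two cores in this assay, a number 2 percentage points lower (within the scatter) from compound 1 to compound 2 and a number 10 percentage points lower (within the scatter) from compound 3 to compound 4, 8 percentage points apart, within the scatter of two such steps. The change therefore carries from the core of compound 1 to the core of compound 3 without a detectable difference between the cores, but each step on its own also lies within the scatter. For the compounds shown here, the notes do not show that removing this methoxy lowers the number on either core, and with only two small steps at a single concentration, they cannot exclude a modest dependence on the core.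

Open, from the compounds shown here alone, is whether another group at this place, such as a hydroxyl or a chlorine atom, would give a step beyond the scatter on either core. Also open, going by these compounds, is whether the same pairs would separate under conditions where the numbers in this assay lie further from those of the present compounds.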